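Chromone acrylamides: aryl versus benzyl on the amide nitrogen

A few compounds are considered here, and "the series" means these few. Any claim that something is new, unique, unknown or untested is made for them only; others in the source may bear on it.

Compound 1 `COc1ccc2c(=O)c(/C=C/C(=O)Nc3ccccc3Cl)coc2c1` gives 29900 nM in a functional assay on A549 cells (Homo sapiens) for inhibition, read by MTT assay, with a stated time of 48 h; a higher number here means a weaker inhibitor, a lower number a stronger inhibitor.
Compound 2 `COc1cccc(NC(=O)/C=C/c2coc3cc(OC)ccc3c2=O)c1` gives 12800 nM in this assay.
Compound 3 `COc1ccc2c(=O)c(/C=C/C(=O)NCc3ccc(F)cc3)coc2c1` is reported only as a limit in this assay, > 100000 nM.

Compound 3 therefore stands at the least potent end of the three measured compounds, at the limit of the assay (the limit of > 100000 nM in this assay, at which 1 of the 3 values shown sits). Compound 4 `COc1ccc(NC(=O)/C=C/c2coc3cc(OC)ccc3c2=O)cc1` differs from it in one place: 4-methoxyphenyl in place of 4-fluorobenzyl on an amide-type nitrogen. Within the data shown here, two measured steps bear on this change, both moving from an aryl to a benzyl group on the same nitrogen. The step of an at least 3.3-fold higher number from compound 1 to compound 3 (0.52 log units; beyond the scatter) and the step of an at least 7.8-fold higher number from compound 2 to compound 3 (0.89 log units; beyond the scatter) both show the benzyl compound weaker. Reversing that move, from benzyl back to an aryl group carrying a methoxy substituent, compound 4 is expected to return towards the range of compound 2, whose value is 12800 nM. For compound 4 the expected step is an at least 6.6-fold lower number from compound 3 to compound 4 (0.82 log units; beyond the scatter). Compound 4 is thus estimated at 15000 nM, with a plausible range from 4000 nM to 60000 nM.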

Compound 4, half-maximal inhibitory concentration: 23000 nM
Estimate against measurement, compound 4: 1.5-fold (0.19 log units) below; the range from low to high includes it.
By their numbers in this assay, from the lowest: compounds 2, 4 and 1 (each within the scatter of the next, the first and the last beyond it). At a limit, above all of these: compound 3.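

Replacing 4-fluorobenzyl with 4-methoxyphenyl gives an at least 4.3-fold lower number from compound 3 to compound 4 (0.63 log units; beyond the scatter) in this assay, so a third aryl group on the amide-type nitrogen now stands clear of the benzyl compound, whose value remains a limit of the assay: the limit of > 100000 nM in this assay, at which 1 of the 4 values shown sits.

The new compound does not separate from its aryl neighbours, with 4-methoxyphenyl in place of 3-methoxyphenyl giving a 1.8-fold higher number from compound 2 to compound 4 (0.25 log units; within the scatter) and 4-methoxyphenyl in place of 2-chlorophenyl giving a 1.3-fold lower number from compound 1 to compound 4 (0.11 log units; within the scatter). Moving the methoxy group therefore leaves no readable change, although compounds 1 and 2 themselves stay apart, by a 2.3-fold lower number from compound 1 to compound 2 (0.37 log units; beyond the scatter).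

The compounds shown leave open whether the loss in compound 3 goes with the benzyl methylene or with its fluorine, which a 4-methoxybenzyl group on the same nitrogen would separate. On these data alone, how an unsubstituted phenyl or a longer chain such as phenethyl would fare there also remains open.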